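Same atoms, joined differently: from compound 3 to compound 4

This account rests on a few compounds, and the source may have more. Where it says the series, first, only, none or still open, it means among the compounds named here.

Of the compounds shown here, three sharing one core have been measured in a functional assay on HCT-116 cells (Homo sapiens) for antiproliferative activity, read by MTT assay, with a stated time of 72 h; on this read-out higher numbers stand for weaker inhibition and lower numbers for stronger inhibition. Compound 1 `O=C(CCc1cccc2c1B(O)OC2)Nc1cccc(Br)c1`, carrying a bromo group, gives 1400 nM. Compound 2 `O=C(CCc1cccc2c1B(O)OC2)Nc1cccc(-c2ccc(F)cc2)c1`, with 4-fluorophenyl in that place, gives 550 nM. Compound 3 `COc1cc(OC)cc(-c2cccc(NC(=O)CCc3cccc4c3B(O)OC4)c2)c1`, with 3,5-dimethoxyphenyl there, gives 53 nM, the lowest number of the three.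

Compound 4 `COc1cc(OC)cc(-c2cccc(NC(=O)CCc3ccc4c(c3)COB4O)c2)c1` keeps the 3,5-dimethoxyphenyl and differs elsewhere: a group of 10 heavy atoms (7 carbon, 1 boron, 2 oxygen; one five-membered non-aromatic ring with 2 hetero atoms, one six-membered aromatic ring of carbon only) in place of a group of 10 heavy atoms (7 carbon, 1 boron, 2 oxygen; one five-membered non-aromatic ring with 2 hetero atoms, one six-membered aromatic ring of carbon only), on a saturated chain carbon, two bonds along the chain from a carbonyl carbon. The two have the same atoms, joined differently.

The measured steps are a 2.5-fold lower number from compound 1 to compound 2 (0.41 log units; beyond the scatter), which is modest, and a 26-fold lower number from compound 1 to compound 3 (1.42 log units; beyond the scatter) and a 10-fold lower number from compound 2 to compound 3 (1.02 log units; beyond the scatter), which are both large. All three exchange the group on an aromatic carbon, and none alters the group that differs here, so they give no direct measure of this step. Among the compounds with values here, they show only that a single change can move the number widely. With compound 3 at 53 nM, the lowest so far, a higher number is the more likely outcome in this assay, though this is uncertain. The expected change is a 4.7-fold higher number from compound 3 to compound 4 (0.67 log units; beyond the scatter), a step beyond the scatter towards weaker inhibition. For compound 4 the estimated value is 250 nM, with an expected range from 50 nM to 1500 nM.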

Compound 4, half-maximal inhibitory concentration: 56000 nM
For compound 4 the middle estimate is 220-fold (2.35 log units) below the measured one, and the stated range ends below it.
By their numbers in this assay, from the lowest: compound 3; then compound 2; then compound 1; then compound 4.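

In this assay, the rearrangement gives a 1100-fold higher number from compound 3 to compound 4 (3.02 log units; beyond the scatter), and none of the other steps shown is as large, even though no atom is added or removed. The group that leaves and the group that enters have the same atoms, the same two rings and the same counts of hydrogen-bond donors and acceptors, so the difference lies only in how those atoms are joined, a kind of change the earlier exchanges on an aromatic carbon could not reveal. Within the data shown here, nothing available here bears on why this rejoining moves the number so far.

The rejoined group is shown only with 3,5-dimethoxyphenyl, so it remains open whether a step of this size would also appear with bromo or 4-fluorophenyl in that place. Also open, as far as these compounds go, is how the number would respond to a longer chain leading to the carbonyl carbon, or to a carboxylic acid in place of the boron-containing group.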